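This account rests on a few compounds, and the source may have more. Where it says the series, first, only, none or still open, it means among the compounds named here.

Three compounds share one core and differ only in the group that sits on a saturated chain carbon bound to a sulfur. In an assay on CHO cells for displacement of a labelled ligand from adenosine receptor A3 (Homo sapiens), read by scintillation counting, with a stated time of 120 min, tested at 1 uM (a higher number here means more inhibition at the concentration tested (going by the name of the read-out), a lower number less inhibition), compound 1 `N#Cc1c(N)nc(SCC(N)=O)c(C#N)c1-c1ccc(OCC2CC2)cc1` gives 8%, compound 2 `N#Cc1c(N)nc(SCc2cccnc2)c(C#N)c1-c1ccc(OCC2CC2)cc1` gives 19%, and compound 3 `N#Cc1c(N)nc(SCc2cnc[nH]2)c(C#N)c1-c1ccc(OCC2CC2)cc1` gives 1%. Compound 3 has the lowest of the three numbers; its gap to compound 1 lies within the scatter, while a number 18 percentage points lower from compound 2 to compound 3 (beyond the scatter). Compound 4 `N#Cc1c(N)nc(SCc2ncn[nH]2)c(C#N)c1-c1ccc(OCC2CC2)cc1` carries the change (1H-1,2,4-triazol-5-yl in place of 1H-imidazol-5-yl on a saturated chain carbon bound to a sulfur). For the measured compounds named here, no measured step exchanges one five-membered aromatic ring for another at this place; the nearest guidance comes from a number 7 percentage points lower from compound 1 to compound 3 (within the scatter) and from a number 11 percentage points higher from compound 1 to compound 2 (beyond the scatter), which show that swapping groups here moves the read-out only modestly, and all three measured numbers stay low. For compound 4 in this assay a step of a number 4 percentage points higher from compound 3 to compound 4 (within the scatter) is therefore expected, which means no change beyond the scatter. The estimated value for compound 4 is 5%, with a range from -8% to 20%.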

Compound 4, a percentage reported as inhibition, at one concentration (the size of the read-out at that concentration, not a potency): 1%
Beside the measured number, compound 4's estimate is 4 percentage points above it; low and high end bracket the measured number.
By their numbers in this assay, from the lowest: compounds 3, 4 and 1 (each within the scatter of the next); then compound 2.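

In this assay, for the compounds shown here, the first comparison of two five-membered aromatic rings on a saturated chain carbon bound to a sulfur shows no change at the digits printed from compound 3 to compound 4 (within the scatter), so 1H-1,2,4-triazol-5-yl and 1H-imidazol-5-yl cannot be told apart here. Compound 4 also sits apart from the pyridin-3-yl group, with a number 18 percentage points lower from compound 2 to compound 4 (beyond the scatter), but not from the carbamoyl group, with a number 7 percentage points lower from compound 1 to compound 4 (within the scatter), which matches what compound 3 showed. Nothing available explains why these numbers fall as they do.

Still open, going by these compounds, is whether a carboxylic acid or an amine on this chain carbon, or a longer chain leading to the ring, would raise the read-out above that of compound 2. Also open, on these data alone, is how a plain phenyl ring would compare with pyridin-3-yl.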